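A few compounds are considered here, and "the series" means these few. Any claim that something is new, unique, unknown or untested is made for them only; others in the source may bear on it.

Compound 1 `Cc1noc(-c2cc3ccccc3[nH]2)n1` in a functional assay on Jurkat cells (Homo sapiens) for antiproliferative activity, read by WST assay, with a stated time of 72 h (on this read-out lower numbers stand for stronger inhibition and higher numbers for weaker inhibition), gives > 50000 nM, which is a limit of the assay rather than a number.
Compound 2 `COc1ccc2[nH]c(-c3nc(C)no3)cc2c1` in this assay gives 19900 nM.
Compound 3 `Cc1noc(-c2cc3cc(Cl)ccc3[nH]2)n1` in this assay gives 21600 nM.

Compound 1 stands at the edge of what the assay reports: the limit of > 50000 nM in this assay, at which 1 of the 3 values shown sits. Both measured steps from it change the shared core on an aromatic carbon of the indole part and both pass the scatter: an at least 2.5-fold lower number from compound 1 to compound 2 (0.40 log units; beyond the scatter), and an at least 2.3-fold lower number from compound 1 to compound 3 (0.36 log units; beyond the scatter). Between the two substituted compounds the difference is small: a 1.1-fold higher number from compound 2 to compound 3 (0.04 log units; within the scatter).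

Compound 4 `Clc1ccc(-c2noc(-c3cc4ccccc4[nH]3)n2)cc1` changes compound 1 at a different place: 4-chlorophenyl in place of methyl on an aromatic carbon. Neither measured step touches this carbon, so none bears directly on the change; they show only that a single substituent on the shared core moves compound 1 off its limit to a measurable number. The expected outcome for compound 4 is a modest move to a lower number, an at least 2.5-fold lower number from compound 1 to compound 4 (0.39 log units; beyond the scatter), though it may well remain at the limit. Compound 4 is estimated at 20000 nM, with a range from 5000 nM to 60000 nM.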

Compound 4, half-maximal inhibitory concentration: > 50000 nM
Compound 4 gave a limit, no number; the forecaster's own chance of this, stated with the estimate: 35%; middle value at least 2.5-fold (0.39 log units) away from the limit.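

In this assay, compound 1 and compound 4 both stand at a limit rather than a number, so the step between them cannot be read: the limit of > 50000 nM in this assay, at which 2 of the 4 values shown sit.

The compounds shown leave open whether 4-chlorophenyl in place of methyl changes activity at all, including on compound 2 or compound 3, which give numbers.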